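Second hydroxy on the cinnamamide ring: pyrrolidine versus piperidine amides

The compounds below may be only part of what the source reports. "The series", "measured", "known", "first", "only" and "open" are said of these compounds alone.

Compound 2 `O=C(/C=C/c1ccc(O)cc1)N1CCCCC1` gives 0.91% in a functional assay, with a stated time of 30 min, tested at 1 mM (a lower number here means less inhibition, a higher number more inhibition at the concentration tested (going by the name of the read-out)), the lowest of the three numbers; compound 1 `O=C(/C=C/c1ccc(O)cc1O)N1CCCC1` gives 22.3% and compound 3 `O=C(/C=C/c1ccc(O)c(O)c1)N1CCCCC1` gives 82.9%. Compound 4 `O=C(/C=C/c1ccc(O)cc1O)N1CCCCC1` differs from compound 2 by hydroxy in place of hydrogen on an aromatic carbon. For the measured compounds named here, the one measured step of this kind, a number 82 percentage points higher from compound 2 to compound 3 (beyond the scatter), places the entering hydroxy elsewhere on the ring. With the same hydroxy pattern as compound 4 but a smaller amine ring, compound 1 gives 22.3%, a modest number. A step is therefore expected beyond the scatter upward, smaller than that to compound 3: a number 24.1 percentage points higher from compound 2 to compound 4 (beyond the scatter). Compound 4 is estimated at 25%, with a range from 10% to 45%.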

Compound 4, a percentage reported as inhibition, at one concentration (the size of the read-out at that concentration, not a potency): 30.7%
Estimate against measurement, compound 4: 5.7 percentage points below; measured number inside the range.
By their numbers in this assay, from the lowest: compound 2; then compounds 1 and 4 (each within the scatter of the next); then compound 3.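

In this assay, for the compounds shown here, hydroxy in place of hydrogen ortho to a large group also counts: a number 29.8 percentage points higher from compound 2 to compound 4 (beyond the scatter), so the gain is not confined to the ring position filled in compound 3, although that step is modest and the one to compound 3 large. With this hydroxy pattern the amine ring does not separate the compounds: a number 8.4 percentage points higher from compound 1 to compound 4 (within the scatter). No evidence on the cause of these steps is available.

As far as these compounds go, whether methoxy in place of this hydroxy keeps the step remains open. So does whether morpholin-4-yl on the carbonyl carbon matches piperidin-1-yl.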